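The source may report more compounds than this note shows. Statements on the series, on what has been measured and on what is new or still open speak of the compounds shown alone.

Compound 1 `Cc1ccc(C(=O)N/N=C/c2cc(I)cc(I)c2O)cc1` gives > 25000 nM in a functional assay on HepG2 cells (Homo sapiens) for cytotoxicity, with a stated time of 24 h (a higher number here means a weaker inhibitor, a lower number a stronger inhibitor), which is a limit of that assay rather than a number. Compound 2 `COc1ccc(C(=O)N/N=C/c2cc(I)cc(I)c2O)cc1` gives 45200 nM. Compound 3 `O=C(N/N=C/c1cc(I)cc(I)c1O)c1ccc(Cl)cc1` gives 14800 nM.

Among the numbers shown, compound 3 stands lowest; its nearest neighbour is compound 2, with the step of a 3.1-fold lower number from compound 2 to compound 3 (0.48 log units; beyond the scatter). Compound 1 sits at the limit (the limit of > 25000 nM in this assay, at which 1 of the 3 values shown sits). The step of an at least 1.6-fold lower number from compound 1 to compound 3 (0.22 log units; that floor lies within the scatter) therefore carries only a floor. Compound 4 `O=C(N/N=C/c1cc(I)cc(I)c1O)c1ccc(Br)cc1` differs from compound 3 by bromo in place of chloro on an aromatic carbon. Among the measured compounds shown here, none of the measured steps swaps one halogen for another; the two steps that introduce chloro lowered the number modestly, and this halogen-for-halogen swap is a smaller change than either. For compound 4 a step of a 1.3-fold lower number from compound 3 to compound 4 (0.13 log units; within the scatter) is therefore expected, small enough to lie within the scatter. Compound 4 is expected to give 11000 nM in this assay, between 4000 nM and 30000 nM.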

Compound 4, half-maximal inhibitory concentration: 22300 nM
Compound 4: the middle estimate sits 2.0-fold (0.31 log units) below what was measured; measured number inside the range.
By their numbers in this assay, from the lowest: compounds 3 and 4 (each within the scatter of the next); then compound 2.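

Swapping chloro for bromo on the aromatic ring, the first halogen-for-halogen change here, gives a 1.5-fold higher number from compound 3 to compound 4 (0.18 log units; within the scatter) in this assay, so this assay does not separate 4-chlorophenyl from 4-bromophenyl. Bromo, like chloro, stands clear of methoxy, with a 2.0-fold lower number from compound 2 to compound 4 (0.31 log units; beyond the scatter). Compound 1 gives a limit rather than a number, so its step offers only a floor, an at least 1.1-fold lower number from compound 1 to compound 4 (0.04 log units; that floor lies within the scatter), and the evidence is this: the limit of > 25000 nM in this assay, at which 1 of the 4 values shown sits.

On these data alone, how an amine or a carboxylic acid at this place would compare with the two halogens stays open. So does the true distance between methyl and bromo.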